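Chlorobenzyl sulfanyl swap at a low-inhibition end of the series

A few compounds are considered here, and "the series" means these few. Any claim that something is new, unique, unknown or untested is made for them only; others in the source may bear on it.

Compound 1 `CC1=C(C(=O)Nc2ccc(F)cc2)C(c2ccc([N+](=O)[O-])cc2)N=C(SCc2ccccc2Cl)N1` gives 3.1% in a functional assay on the whole organism (artery, strain albino) with Rattus norvegicus as the target, with a stated time of 30 min, at a dose of 10 mg/kg by the oral route; on this read-out lower numbers stand for less inhibition and higher numbers for more inhibition at the one dose given (going by the name of the read-out). Compound 2 `CC1=C(C(=O)Nc2ccc(F)cc2)C(c2ccc([N+](=O)[O-])cc2)N=C(SCc2cccc(Cl)c2)N1` carries 3-chlorophenyl in place of 2-chlorophenyl on a saturated chain carbon bound to a sulfur and in this assay compound 2 gives 4.1%; the step of a number 1 percentage points higher from compound 1 to compound 2 (within the scatter). Compound 3 `CC1=C(C(=O)Nc2ccc(Br)cc2)C(c2ccc(Cl)cc2Cl)N=C(SCc2ccccc2Cl)N1` shares a core whose difference from that of compound 1 is not broken down here, and in this assay compound 3 gives 5.7%. Compound 4 `CC1=C(C(=O)Nc2ccc(Br)cc2)C(c2ccc(Cl)cc2Cl)N=C(SCc2cccc(Cl)c2)N1` is not yet measured; it carries 3-chlorophenyl in place of 2-chlorophenyl on a saturated chain carbon bound to a sulfur, the same change made from compound 1 to compound 2. Because a number 1 percentage points higher from compound 1 to compound 2 (within the scatter), the step for compound 4 is expected to be a number 1 percentage points higher from compound 3 to compound 4 (within the scatter). With that reasoning compound 4 is estimated at 6.7%, between 0% and 15%.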

Compound 4, a percentage reported as inhibition, in the whole organism at one dose (the size of the read-out at that dose, not a potency): 3.1%
For compound 4 the middle estimate is 3.6 percentage points above the measured one, within the range that was stated.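

In this assay, the swap of 2-chlorobenzyl to 3-chlorobenzyl on the second core gives a number 2.6 percentage points lower from compound 3 to compound 4 (within the scatter). Set beside the earlier step, the swap shows no difference between the two cores that can be told apart: the same change on two cores in this assay, a number 1 percentage points higher (within the scatter) from compound 1 to compound 2 and a number 2.6 percentage points lower (within the scatter) from compound 3 to compound 4, 3.6 percentage points apart, within the scatter of two such steps. Neither step stands clear of the scatter, so the pair shows no measurable effect of the swap on either core; it does not establish that a real effect carries from one core to the other.

Still open, from the compounds shown here alone, is whether any group on the sulfur can move this read-out beyond the scatter. The compounds shown leave unanswered how a longer chain, or a benzyl carrying an amine or a carboxylic acid, would read on these cores.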